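The source may hold more compounds than are shown below. What is called first, only, known or untested is meant among the compounds shown, and "the series" means these compounds.

Compound 1 `CNC(=O)CC1CCc2cc(OC)c(OC)cc21`: 15.6%
Compound 2 `CCNC(=O)CC1CCc2cc(OC)c(OC)cc21`: 15.6%

In a functional assay on the whole organism (strain Wistar) for inhibition, with Rattus norvegicus as the target, read by paw edema, with stated times of 60 min and 1 h, at a dose of 100 mg/kg by the oral route (on this read-out higher numbers stand for more inhibition at the one dose given (going by the name of the read-out) and lower numbers for less inhibition), compound 2 gives 15.6%, level with compound 1 within the scatter. Compound 3 `COc1cc2c(cc1OC)C(CC(=O)NCc1ccccc1)CC2` differs from compound 2 by phenyl in place of methyl on a saturated chain carbon bound to an amide-type nitrogen. For the measured compounds named here, the only measured step, no change at the digits printed from compound 1 to compound 2 (within the scatter), alters the same saturated chain carbon bound to an amide-type nitrogen with a smaller group and shows no movement beyond the scatter. Going by the values given here, no measured step places a phenyl there, so the expected step of a number 4.4 percentage points higher from compound 2 to compound 3 (within the scatter) is uncertain in size, with at most a modest rise anticipated. Compound 3 is estimated at 20%, within 3% to 45%.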

Compound 3, a percentage reported as inhibition, in the whole organism at one dose (the size of the read-out at that dose, not a potency): 18.8%
Estimate against measurement, compound 3: 1.2 percentage points above; measured number inside the range.
By their numbers in this assay, from the lowest: compounds 1, 2 and 3 (each within the scatter of the next).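

Phenyl on the saturated chain carbon bound to an amide-type nitrogen gives a number 3.2 percentage points higher from compound 2 to compound 3 (within the scatter) in this assay and a number 3.2 percentage points higher from compound 1 to compound 3 (within the scatter) as well. The earlier step covered only a methyl, whereas this one shows that a six-membered aromatic ring can stand at this place with no movement beyond the scatter. Nothing available explains why the numbers stay so close.

On these data alone, whether a longer chain carrying the phenyl would move the read-out remains open. So does the effect of an amine or a carboxylic acid at this place.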